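Trichloroethyl to benzyl change in this series

The source may hold more compounds than are shown below. What is called first, only, known or untested is meant among the compounds shown, and "the series" means these compounds.

In an ADME assay for pharmacokinetics, in simulated intestinal fluid (on this read-out higher numbers stand for a longer-lived compound and lower numbers for a shorter-lived compound), compound 2 `CCOc1cc(NC(=O)C2(NC(=O)c3ccc4c(C5CCCC5)c(-c5ncc(Cl)cn5)n(C)c4c3)CCC2)ccc1/C=C/C(=O)OCC(Cl)(Cl)Cl` gives > 5 h, which is a limit of the assay and not a number. Within the data shown here, compound 1 `CCOc1cc(NC(=O)C2(NC(=O)c3ccc4c(C5CCCC5)c(-c5ncc(Cl)cn5)n(C)c4c3)CCC2)ccc1/C=C/C(=O)N[C@@H](CC(=O)O)C(N)=O` gives 0.0667 h in this assay, and the only measured step, an at least 74-fold higher number from compound 1 to compound 2 (1.87 log units; beyond the scatter), ends at the limit of > 5 h in this assay, at which 1 of the 2 values shown sits. Compound 3 `CCOc1cc(NC(=O)C2(NC(=O)c3ccc4c(C5CCCC5)c(-c5ncc(Cl)cn5)n(C)c4c3)CCC2)ccc1/C=C/C(=O)OCc1ccccc1` differs from compound 2 by phenyl in place of trichloromethyl on a saturated chain carbon bound to an oxygen next to a carbonyl group. Among the measured compounds shown here, no measured step alters this part of the molecule between two numbered values, so that step is only a loose guide. The step from compound 2 to compound 3 is expected to be a number no higher from compound 2 to compound 3 (the limit leaves the size open). Compound 3 is therefore estimated at 5 h, with a range of 1.5 h to 20 h.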

Compound 3, half-life: > 5 h
Compound 3 gave a limit, no number (the forecaster's own chance of this, stated with the estimate: 50%); the middle value sits exactly at the limit.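

In this assay the benzyloxy group on a carbonyl carbon gives an at least 74-fold higher number from compound 1 to compound 3 (1.87 log units; beyond the scatter), so the long half-life does not depend on 2,2,2-trichloroethoxy alone and also holds with an aromatic ring in that group. The step between compound 2 and compound 3 cannot be read, and both values are limits of the assay: the limit of > 5 h in this assay, at which 2 of the 3 values shown sit.

On these data alone, how far either compound lies past that limit stays open. Also open, as far as these compounds go, is whether a methoxy group or a carboxylic acid on the same carbonyl carbon would stay at the limit or fall towards compound 1.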